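Removing a ring ethyl group from a glucagon receptor antagonist

The compounds below may be only part of what the source reports. "The series", "measured", "known", "first", "only" and "open" are said of these compounds alone.

Of the compounds shown here, two have been measured in a functional assay on CHO cells for antagonist activity at Glucagon receptor (Homo sapiens), read by cAMP accumulation, with stated times of 30 min and 45 min; on this read-out lower numbers stand for stronger inhibition and higher numbers for weaker inhibition. Compound 1 `CC(C)(C)CC[C@H](c1ccc(C(=O)NCc2nn[nH]n2)cc1)N1C(=O)C(c2cccc(C(F)(F)F)c2)=N[C@]12CC[C@@H](C(C)(C)C)CC2` gives 180 nM. Compound 2 `CC[C@H]1CC[C@]2(CC1)N=C(c1cc(Cl)cc(Cl)c1)C(=O)N2[C@H](CCC(C)(C)C)c1ccc(C(=O)NCc2nn[nH]n2)cc1` gives 66 nM, the lowest of the two numbers; compound 1 sits beyond the scatter above it. The two differ in more than one place, so no single change can be read from that gap.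

Compound 3 `CC(C)(C)CC[C@H](c1ccc(C(=O)NCc2nn[nH]n2)cc1)N1C(=O)C(c2cc(Cl)cc(Cl)c2)=NC12CCCCC2` keeps everything of compound 2 except one change: hydrogen in place of ethyl on a saturated ring carbon. Among the measured compounds shown here, no measured pair shows this change alone, so the size of its effect is unknown. Because compound 2 gives 66 nM as the lower of the two measured numbers, taking a group away from it is expected to cost some potency, an estimated step of a 2.3-fold higher number from compound 2 to compound 3 (0.36 log units; beyond the scatter). Compound 3 is therefore expected to give about 150 nM, within a range from 60 nM to 400 nM.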

Compound 3, half-maximal inhibitory concentration: 510 nM
For compound 3 the middle estimate is 3.4-fold (0.53 log units) below the measured one, outside the stated range (above it).
By their numbers in this assay, from the lowest: compound 2; then compound 1; then compound 3.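

In this assay, putting hydrogen in place of ethyl on the saturated ring carbon gives a 7.7-fold higher number from compound 2 to compound 3 (0.89 log units; beyond the scatter). Among the compounds shown here, this isolates the change for the first time and shows that inhibition depends on what this ring position carries, with the ethyl group giving the stronger result of the two. Nothing available explains why this small group makes such a difference.

On these data alone, it remains open whether a methyl group, a longer chain or a hydroxyl group on this carbon would give a number closer to that of compound 2 or that of compound 3. It is also unclear whether removing the ethyl group would cost as much in a molecule carrying the trifluoromethyl group of compound 1.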